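This account rests on a few compounds, and the source may have more. Where it says the series, first, only, none or still open, it means among the compounds named here.

Measured so far:
compound 1 `CCOC(=O)CN(Cc1ccccc1)c1nc(NCc2cccc(OC)c2)ncc1[N+](=O)[O-]` — 57400 nM
compound 2 `COC(=O)CN(C)c1nc(Nc2ccccc2)ncc1[N+](=O)[O-]` — > 100000 nM

Among the measured compounds shown here, in a functional assay on MCF7 cells (Homo sapiens) for antiproliferative activity, read by MTT assay, with a stated time of 48 h (a lower number here means a stronger inhibitor, a higher number a weaker inhibitor), compound 1 gives 57400 nM, the only plain number among the two values shown. For compound 2 the result in this assay is a limit only, > 100000 nM. This is the limit of > 100000 nM in this assay, at which 1 of the 2 values shown sits.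

Compound 3 `CCOC(=O)CNc1ncc([N+](=O)[O-])c(N(CC(=O)OCC)Cc2ccccc2)n1` is not yet measured. It carries ethoxycarbonyl in place of 3-methoxyphenyl on a saturated chain carbon bound to a nitrogen on an aromatic ring. For the measured compounds named here, no measured pair shows what this change does, so the step is open. Since compound 1 already stands at 57400 nM, compound 3 is expected to shift by a 1.7-fold higher number from compound 1 to compound 3 (0.24 log units; within the scatter), toward weaker inhibition. Compound 3 is estimated at 100000 nM, between 40000 nM and 300000 nM.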

Compound 3, half-maximal inhibitory concentration: > 100000 nM
Compound 3 ended at the assay's limit (the forecaster's own chance of this, stated with the estimate: 50%); the middle value sits exactly at the limit.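

In this assay, among the compounds shown here, the change to ethoxycarbonyl from 3-methoxyphenyl on a saturated chain carbon bound to a nitrogen on an aromatic ring gives an at least 1.7-fold higher number from compound 1 to compound 3 (0.24 log units; that floor lies within the scatter) and so provides the first reading at this position. Compound 3 reaches only a limit, so this step is a floor, and a loss beyond the scatter is not established. Compound 1 alone carries a plain number in this set: the limit of > 100000 nM in this assay, at which 2 of the 3 values shown sit.

On these data alone, whether unsubstituted phenyl, a carboxylic acid or an amine in this place would give a plain number stays open. As far as these compounds go, the true size of the step also stays open.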